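Amide chain extension on the shared core

This account rests on a few compounds, and the source may have more. Where it says the series, first, only, none or still open, it means among the compounds named here.

Measured compounds in an assay for binding affinity to 5-hydroxytryptamine receptor 1F (Homo sapiens), read by radioligand binding; on this read-out lower numbers stand for stronger inhibition and higher numbers for weaker inhibition:
Compound 1, `Cc1cccc(C(=O)Nc2ccc3[nH]cc(C4CCN(C)CC4)c3n2)c1`: compound 1 gives 5.8 nM
Compound 2, `Cc1ccc(C(=O)Nc2ccc3[nH]cc(C4CCN(C)CC4)c3n2)cc1`: compound 2 gives 12 nM
Compound 3, `CCCC(=O)Nc1ccc2[nH]cc(C3CCN(C)CC3)c2n1`: compound 3 gives 6.9 nM

Compound 3 holds the second highest of the three numbers in this assay. Its nearest neighbour is reached by a 1.2-fold higher number from compound 1 to compound 3 (0.08 log units; within the scatter), its furthest by a 1.7-fold lower number from compound 2 to compound 3 (0.24 log units; within the scatter), so all three amides sit within the scatter of one another except for a 2.1-fold higher number from compound 1 to compound 2 (0.32 log units; beyond the scatter).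

Compound 4, `CCCCC(=O)Nc1ccc2[nH]cc(C3CCN(C)CC3)c2n1`, differs from compound 3 by methyl in place of hydrogen on a saturated chain carbon, three bonds along the chain from a carbonyl carbon. Going by the values given here, no measured step alters the chain length of the acyl group; the only steps that touch the carbonyl substituent are the two swaps of an aryl group for propyl, and both stay within the scatter. On that basis no step beyond the scatter is expected for compound 4 in this assay, in either direction; the data give no lead on which way a butyl chain would move the number.

Compound 4 is estimated at 7.5 nM, with a range from 3 nM to 18 nM. This estimate means a 1.1-fold higher number from compound 3 to compound 4 (0.04 log units; within the scatter), expected to lie within the scatter.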

Compound 4, inhibition constant: 14 nM
The estimate for compound 4 lay 1.9-fold (0.27 log units) below the measured number; measured number inside the range.
By their numbers in this assay, from the lowest: compounds 1, 3, 2 and 4 (each within the scatter of the next, the first and the last beyond it).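

Going by these compounds alone, this is the one measured step that alters the length of the acyl chain in this assay, and adding a single methyl at this position, three bonds along the chain from the carbonyl carbon, moves the number beyond the scatter (a 2.0-fold higher number from compound 3 to compound 4 (0.31 log units; beyond the scatter)). The butyl amide also stands apart from one aryl amide (a 2.4-fold higher number from compound 1 to compound 4 (0.38 log units; beyond the scatter)) but not from the other (a 1.2-fold higher number from compound 2 to compound 4 (0.07 log units; within the scatter)), so swapping an aryl group for a saturated chain on the carbonyl carbon does not give one outcome across the series. Nothing measured here explains the chain-length step.

With only propyl and butyl as saturated chains, the compounds shown cannot establish a trend with chain length. From the compounds shown here alone, how a shorter ethyl chain, a longer pentyl chain, or an amine or carboxylic acid at the chain end would read in this assay remains open.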